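Cyano in Place of Bromo: Estimating Compound 3

The source may report more compounds than this note shows. Statements on the series, on what has been measured and on what is new or still open speak of the compounds shown alone.

Compound 1 `COc1cccc(C(=O)NN(C(=O)c2ccccc2Cl)C(C)(C)C)c1`: 52.5 nM
Compound 2 `CC(C)(C)N(NC(=O)c1ccc(Br)cc1)C(=O)c1ccccc1Cl`: 33.9 nM

In an assay on cells for agonist activity at ecdysone receptor (Bombyx mori), read by a luciferase reporter, with a stated time of 24 h (on this read-out lower numbers stand for an effect already at smaller amounts and higher numbers for an effect only at larger amounts of compound), compound 2 gives 33.9 nM, the lowest of the two numbers, and compound 1 stands nearest with 52.5 nM. For the measured compounds named here, the only measured step, a 1.5-fold lower number from compound 1 to compound 2 (0.19 log units; within the scatter), stays within the scatter. Compound 3 `CC(C)(C)N(NC(=O)c1ccc(C#N)cc1)C(=O)c1ccccc1Cl` differs from compound 2 by cyano in place of bromo on an aromatic carbon. Going by the values given here, no measured step involves a cyano group; the one step that bears on a change of the same ring substituent, a 1.5-fold lower number from compound 1 to compound 2 (0.19 log units; within the scatter), was small. Compound 3 is therefore expected to show no step beyond the scatter, a 1.2-fold higher number from compound 2 to compound 3 (0.07 log units; within the scatter). The estimated value for compound 3 in this assay is 40 nM, with a range from 15 nM to 120 nM.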

Compound 3, half-maximal effective concentration: 603 nM
Compound 3: the middle estimate sits 15-fold (1.18 log units) below what was measured; the measured number lies above the stated range.
By their numbers in this assay, from the lowest: compounds 2 and 1 (each within the scatter of the next); then compound 3.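

In this assay, this place on the ring, para to a large group, no longer looks indifferent to its substituent: cyano in place of bromo gives an 18-fold higher number from compound 2 to compound 3 (1.25 log units; beyond the scatter) and so goes beyond the scatter, which the earlier change of ring substituent did not. The 4-cyanophenyl group also stands apart from 3-methoxyphenyl, with an 11-fold higher number from compound 1 to compound 3 (1.06 log units; beyond the scatter) as the step. Nothing available here explains this large rise in the number.

The compounds shown leave open whether the rise is particular to the cyano group. An amine, a carboxylic acid or a methyl group in the same place could show either a similarly large step or none.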